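Pentyl extension on the aromatic ring of compound 1

This account rests on a few compounds, and the source may have more. Where it says the series, first, only, none or still open, it means among the compounds named here.

Within the data shown here, compound 1 `CN1O[C@@H](n2cc(-c3ccccc3)nn2)C[C@@H]1CO` stands at the top of the two numbers measured so far in a functional assay on FTC-133 cells (Homo sapiens) for cytotoxicity, read by MTT assay, with a stated time of 24 h (on this read-out higher numbers stand for weaker inhibition and lower numbers for stronger inhibition), at 6030 nM, though its only neighbour lies within the scatter of it. Among the measured compounds shown here, that neighbour is compound 2 `CCCc1cn([C@H]2C[C@H](CO)N(C)O2)nn1`, which in this assay gives 3870 nM; the one measured step, a 1.6-fold lower number from compound 1 to compound 2 (0.19 log units; within the scatter), exchanges phenyl for propyl on the aromatic carbon of the shared core and stays within the scatter. Compound 3 `CCCCCc1ccc(-c2cn([C@H]3C[C@H](CO)N(C)O3)nn2)cc1` keeps the phenyl of compound 1 and differs from it by pentyl in place of hydrogen on an aromatic carbon. For the measured compounds named here, no measured step adds a chain to a retained aromatic ring, so the propyl-for-phenyl exchange is the only comparison at hand, and it shows that a sizeable change at this carbon moved the read-out little. The expectation is therefore no step beyond the scatter, and the estimate for compound 3 in this assay is 5000 nM with a range of 2000 nM to 12000 nM. For compound 3 this corresponds to an expected step of a 1.2-fold lower number from compound 1 to compound 3 (0.08 log units; within the scatter).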

Compound 3, half-maximal inhibitory concentration: 3950 nM
Beside the measured number, compound 3's estimate is 1.3-fold (0.10 log units) above it; measured number inside the range.
By their numbers in this assay, from the lowest: compounds 2, 3 and 1 (each within the scatter of the next).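

In this assay, among these compounds, the new step, a 1.5-fold lower number from compound 1 to compound 3 (0.18 log units; within the scatter), is the first read on a chain added to a retained phenyl, whereas the earlier step, a 1.6-fold lower number from compound 1 to compound 2 (0.19 log units; within the scatter), replaced the phenyl altogether. Pentyl in place of hydrogen, on an aromatic carbon para to a large group, adds five carbon atoms without carrying the number beyond the scatter of compound 1, so for this one substituent the extended and the unextended phenyl cannot be told apart on this read-out. No measurement available here explains this flat response at this position, so it stands as an observation only.

Open, from the compounds shown here alone, is whether an amine, a carboxylic acid or a longer chain in the same place would give a step beyond the scatter, or would stay as flat as pentyl does. With no step among the compounds shown lying beyond the scatter, the series does not yet show how large a change at this position must be to move the read-out, or whether any such change does so.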